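Salicylanilide series: removing the chloro from compound 2

A few compounds are considered here, and "the series" means these few. Any claim that something is new, unique, unknown or untested is made for them only; others in the source may bear on it.

Measured compounds:
compound 1, `COc1ccc(O)c(C(=O)Nc2ccc(C#N)cc2)c1`: > 10000 nM
compound 2, `N#Cc1ccc(NC(=O)c2ccc(Br)cc2O)cc1Cl`: 960 nM

Both values come from a functional assay on KG-1 cells (Homo sapiens) for cytotoxicity, read by luminescence and CellTiter-Glo, with a stated time of 3 days; on this read-out lower numbers stand for stronger inhibition and higher numbers for weaker inhibition. For compound 1 the result is a limit of the assay, > 10000 nM, and not a number; it sits at the limit of > 10000 nM in this assay, at which 1 of the 2 values shown sits. For the measured compounds named here, compound 2, `N#Cc1ccc(NC(=O)c2ccc(Br)cc2O)cc1Cl`, gives 960 nM in this assay, the only numerical value in the set; the pair of compounds differ in several places at once, so the gap between them cannot be traced to any one change.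

The next compound, compound 3, `N#Cc1ccc(NC(=O)c2ccc(Br)cc2O)cc1`, differs from compound 2 in one place only: hydrogen in place of chloro on an aromatic carbon. The chloro sits ortho to a cyano group and meta to a large group. With no measured step of this kind in the set, the direction is not fixed by data. A modest weakening is expected, so that the step from compound 2 to compound 3 in this assay is estimated at a 2.6-fold higher number from compound 2 to compound 3 (0.42 log units; beyond the scatter), a change at or just beyond the scatter. Compound 3 is expected to give about 2500 nM in this assay, within a range of 800 nM to 8000 nM.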

Compound 3, half-maximal inhibitory concentration: 1450 nM
Compound 3: the middle estimate sits 1.7-fold (0.24 log units) above what was measured; low and high end bracket the measured number.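

For the compounds shown here, the step in this assay is a 1.5-fold higher number from compound 2 to compound 3 (0.18 log units; within the scatter), and it is the first comparison that isolates a single place on the core. It shows that, for this pair, chloro and hydrogen on this aromatic carbon, ortho to a cyano group and meta to a large group, cannot be told apart in this read-out, so the chloro is not required for compound 3 to stay in the same range as compound 2. Nothing at hand gives a cause for this result, and the pair fixes only the size of this one exchange, not any reason for it.

Going by these compounds, only hydrogen and chloro are seen at this place, so it remains open whether a methyl, an amine or a bromo there would also stay within the scatter of these two or would move the number clearly in either direction. Also open, on these data alone, is how much the hydroxy and the bromo on the other ring of compound 3 each contribute, for example with an amine in place of the hydroxy or a methyl in place of the bromo.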